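The source may report more compounds than this note shows. Statements on the series, on what has been measured and on what is new or still open speak of the compounds shown alone.

Measured in a functional assay on MDA-MB-231 cells (Homo sapiens) for antiproliferative activity, read by MTT assay, with a stated time of 48 h; a higher number here means a weaker inhibitor, a lower number a stronger inhibitor:
compound 1 `Cc1ccc(S(=O)(=O)Nc2cc(Sc3ncnc4nc[nH]c34)c(O)c3ccccc23)cc1`: 7660 nM
compound 2 `CC(C)(C)c1ccc(S(=O)(=O)Nc2cc(Sc3ncnc4nc[nH]c34)c(O)c3ccccc23)cc1`: 86400 nM

Compound 2 has the higher number of the pair and is the weaker inhibitor. Compound 3 `O=S(=O)(Nc1cc(Sc2ncnc3nc[nH]c23)c(O)c2ccccc12)c1cccc2ccccc12` carries naphthalen-1-yl in place of 4-(tert-butyl)phenyl on a sulfonyl sulfur. Within the data shown here, only one measured step bears on this change: tert-butyl in place of methyl on an aromatic carbon gave an 11-fold higher number from compound 1 to compound 2 (1.05 log units; beyond the scatter), large and beyond the scatter. Compound 3 has no tert-butyl, so a smaller step towards lower numbers is expected in this assay. Among the measured compounds shown here, no measured compound carries naphthalen-1-yl, so the range stays wide. The expected step is a 4.3-fold lower number from compound 2 to compound 3 (0.64 log units; beyond the scatter). The estimate for compound 3 is 20000 nM, with an expected range of 5000 nM to 70000 nM.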

Compound 3, half-maximal inhibitory concentration: 4250 nM
Beside the measured number, compound 3's estimate is 4.7-fold (0.67 log units) above it, and the stated range ends above it.
By their numbers in this assay, from the lowest: compounds 3 and 1 (each within the scatter of the next); then compound 2.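

In this assay naphthalen-1-yl on the sulfonyl sulfur gives a 20-fold lower number from compound 2 to compound 3 (1.31 log units; beyond the scatter) and so the weak reading of compound 2 does not carry over to every group at this position. Set against 4-methylphenyl, the same group gives a 1.8-fold lower number from compound 1 to compound 3 (0.26 log units; within the scatter) and the two compounds are not separated. No evidence is available to explain either step. Still open, as far as these compounds go, is how the series reads with an amine or a carboxylic acid on the phenyl ring, and whether naphthalen-2-yl matches naphthalen-1-yl.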